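The compounds below may be only part of what the source reports. "The series", "measured", "known", "first", "only" and "open" are said of these compounds alone.

This piece concerns three measured compounds and a fourth awaiting measurement. Compound 2 `CCCOc1nc(N)nc2c1ncn2/C=C1/CC1(CO)CO` was tested in an ADME assay on Akata cells (Homo sapiens) for cytotoxicity, with a stated time of 7 days (a higher number here means that more compound is tolerated, a lower number that less compound is tolerated), where it gave only a limit, > 20000 nM. Compound 1 `Nc1nc(NC2CCCCC2)c2ncn(/C=C3/CC3(CO)CO)c2n1` likewise reached only a limit of > 24000 nM. Compound 3 `CCCCCCSc1nc(N)nc2c1ncn2/C=C1/CC1(CO)CO` also stopped at a limit, > 20000 nM. So compound 2 stands where every value shown stands: at the limit of > 20000 nM in this assay, at which 2 of the 3 values shown sit, or at the limit of > 24000 nM in this assay, at which 1 of the 3 values shown sits, with no number that would set it apart from the others.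

Compound 4 `Nc1nc(N2CCCC2)c2ncn(/C=C3/CC3(CO)CO)c2n1` differs from compound 2 in one place: pyrrolidin-1-yl in place of propoxy on an aromatic carbon. The measured steps that come closest are a step that the two limits leave unreadable from compound 1 to compound 2 and a step that the two limits leave unreadable from compound 2 to compound 3, and neither yields a readable size, since both ends rest on a limit. With all three values sitting at a limit, the expectation for compound 4 is a step that the limit leaves unreadable from compound 2 to compound 4, which means no change beyond the scatter. Compound 4 is accordingly estimated at 25000 nM, between 15000 nM and 60000 nM, and is expected to be reported once more only as a limit.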

Compound 4, half-maximal cytotoxic concentration: > 24000 nM
Compound 4: no number, only a limit (the forecaster's own chance of this, stated with the estimate: 85%); the middle value lies beyond the limit too.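

Compound 4 also gives only a limit in this assay, > 24000 nM. Within the data shown here, with all four compounds resting on limits, no step from compound 1, compound 2 or compound 3 to compound 4 can be read. The compounds shown leave open at what concentration any of them becomes cytotoxic, and whether these groups differ at all.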